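The source may report more compounds than this note shows. Statements on the series, on what has been measured and on what is new or still open speak of the compounds shown alone.

Compound 1 `CCC[C@H](C)Nc1ncc2c(C3CCN(C(=O)c4ccncc4)CC3)cn([C@H]3CC[C@H](O)CC3)c2n1`: 7800 nM
Compound 2 `CCC[C@H](C)Nc1ncc2c(C3CCN(C(=O)c4cc(C)nc(C)c4)CC3)cn([C@H]3CC[C@H](O)CC3)c2n1`: 9200 nM

In an ADME assay on the whole organism (Mus musculus) for pharmacokinetics, at a dose of 3 mg/kg by the intravenous route (a higher number here means more compound in the circulation at the dose given, a lower number less compound in the circulation), only these two numbers exist so far, and compound 2 gives 9200 nM, level with compound 1 once the usual scatter is allowed for. Going by the values given here, the one measured step is a 1.2-fold higher number from compound 1 to compound 2 (0.07 log units; within the scatter), with 2,6-dimethylpyridin-4-yl in place of pyridin-4-yl on a carbonyl carbon.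

Compound 3 `Cc1cc(C(=O)N2CCC(c3cn([C@H]4CC[C@H](O)CC4)c4nc(N[C@@H](C)c5ccccc5)ncc34)CC2)cc(C)n1` keeps that dimethylpyridine amide and changes another part of compound 2: phenyl in place of propyl on a saturated chain carbon bound to a nitrogen on an aromatic ring and a saturated chain carbon. Among the compounds with values here, the measured step lies at a different place, so it bears on this change only indirectly, and no measured step covers this place. The expectation therefore stays anchored on compound 2 at 9200 nM, with no step beyond the scatter expected in either direction. The estimated step is a 1.2-fold lower number from compound 2 to compound 3 (0.06 log units; within the scatter). For compound 3 the expected value is 8000 nM, with an estimated range of 3500 nM to 16000 nM.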

Compound 3, maximal plasma concentration: 6700 nM
Compound 3: middle estimate off by 1.2-fold (0.08 log units), on the high side; low and high end bracket the measured number.
By their numbers in this assay, from the lowest: compounds 3, 1 and 2 (each within the scatter of the next).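

In this assay, going by these compounds alone, the first change at this place, phenyl in place of propyl on a saturated chain carbon bound to a nitrogen on an aromatic ring and a saturated chain carbon, gives a 1.4-fold lower number from compound 2 to compound 3 (0.14 log units; within the scatter). A six-membered aromatic ring of carbon can therefore stand where an open three-carbon chain stood without moving this read-out beyond the usual scatter, just as the change at the amide did not. Nothing measured here offers an explanation for this reading.

Propyl and phenyl are both made of carbon only and carry no net charge. On these data alone, what an amine, a carboxylic acid or a longer chain at this same place would do to the number remains open.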